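Bromo on the core: the step from compound 2 to compound 4

A few compounds are considered here, and "the series" means these few. Any claim that something is new, unique, unknown or untested is made for them only; others in the source may bear on it.

Compound 2 `N#Cc1ccc(NC(=O)c2ccc3cccnc3c2O)cc1` stands at the lowest of the three numbers recorded in a functional assay on Jurkat cells (Homo sapiens) for cytotoxicity, read by luminescence and CellTiter-Glo, with a stated time of 3 days (on this read-out higher numbers stand for weaker inhibition and lower numbers for stronger inhibition), where compound 2 gives 180 nM. Compound 3 `Cc1cc(C#N)ccc1NC(=O)c1ccc2cccnc2c1O` gives 270 nM in this assay, and the step of a 1.5-fold higher number from compound 2 to compound 3 (0.18 log units; within the scatter) is within the scatter, so these two cannot be ordered. Compound 1 `N#Cc1ccc(NC(=O)c2ccc3cccnc3c2O)c(Cl)c1` gives 550 nM in this assay; the steps of a 3.1-fold lower number from compound 1 to compound 2 (0.49 log units; beyond the scatter) and a 2.0-fold lower number from compound 1 to compound 3 (0.31 log units; beyond the scatter) are both beyond the scatter, though modest.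

Compound 4 `N#Cc1ccc(NC(=O)c2cc(Br)c3cccnc3c2O)cc1` has not been measured. It differs from compound 2 by bromo in place of hydrogen on an aromatic carbon, the change sitting on the shared core, para to the hydroxy group. Every measured step concerns the other ring, the one carrying the nitrile, where chloro, hydrogen and methyl were exchanged; none touches the core. Going by the values given here, there is thus no step of the same kind to lean on, and the measured steps bear on the new change only in showing that small exchanges have moved the number by modest amounts at most. For compound 4 the expected step is no change at the digits printed from compound 2 to compound 4 (within the scatter), that is, none beyond the scatter, with wide uncertainty in either direction. Compound 4 is accordingly estimated at 180 nM, with a range of 60 nM to 600 nM.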

Compound 4, half-maximal inhibitory concentration: 230 nM
Compound 4: middle estimate off by 1.3-fold (0.11 log units), on the low side; the measured number falls inside the stated range.
By their numbers in this assay, from the lowest: compounds 2, 4 and 3 (each within the scatter of the next); then compound 1.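

Going by these compounds alone, this is the first look at the shared core itself, since the earlier steps all concerned the ring carrying the nitrile, and it shows that bromo can stand on this aromatic carbon, para to a hydroxy group, without a readable shift in this assay: the step is a 1.3-fold higher number from compound 2 to compound 4 (0.11 log units; within the scatter) and so compound 2 and compound 4 cannot be ordered. The core position therefore accepts a single bromine atom in place of hydrogen on this read-out, while on the other ring the exchange of chloro for hydrogen gave a step beyond the scatter, though the two changes differ in both group and place and are not directly comparable. No measurement is available that would explain this outcome.

One group at one position cannot show how open this carbon is in general: an amine, a carboxylic acid or a longer chain such as a propyl group here could give a quite different number. Also open, as far as these compounds go, is whether bromo on the core would leave the number as little changed when chloro or methyl stands on the nitrile-bearing ring.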